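The compounds below may be only part of what the source reports. "The series", "measured", "known", "first", "only" and "open" are said of these compounds alone.

Compound 2 `CCN(CC)C(=O)C1=C(C)NC(=O)NC1c1ccco1` is the point of departure. In an assay on membranes from CHO cells for displacement of a labelled ligand from adenosine receptor A1 (Homo sapiens), read by scintillation counting, with a stated time of 60 min, tested at 1 uM (on this read-out lower numbers stand for less inhibition and higher numbers for more inhibition at the one concentration tested (going by the name of the read-out)), compound 2 gives 11%. Its nearest neighbour, compound 3 `CCN(CC)C(=O)C1=C(C)NC(=O)NC1c1ccsc1`, gives 11% in this assay, and compound 1 `CCCC(=O)C1=C(C)NC(=O)NC1c1ccco1` gives 1%; the step of a number 10 percentage points higher from compound 1 to compound 2 (within the scatter) and the step of no change at the digits printed from compound 2 to compound 3 (within the scatter) both fall within the scatter, so all three numbers sit together near the bottom of the read-out and none can be set above another.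

Compound 4 `CC1=C(C(=O)OC2CCCC2)C(c2ccco2)NC(=O)N1` differs from compound 2 in one place: cyclopentyloxy in place of diethylamino on a carbonyl carbon. Among the compounds with values here, only one measured step touches the same carbonyl carbon, the change from propyl to diethylamino in a number 10 percentage points higher from compound 1 to compound 2 (within the scatter), and it stayed within the scatter; the step of no change at the digits printed from compound 2 to compound 3 (within the scatter) concerns a different position and offers no guidance on this exchange. With both known steps flat, the account expects that compound 4 will show no movement beyond the scatter, a step of a number 3 percentage points lower from compound 2 to compound 4 (within the scatter). The expected value for compound 4 in this assay is 8%, within a range from 0% to 25%.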

Compound 4, a percentage reported as inhibition, at one concentration (the size of the read-out at that concentration, not a potency): 1%
The estimate for compound 4 lay 7 percentage points above the measured number; measured number inside the range.
By their numbers in this assay, from the lowest: compounds 1, 4, 2 and 3 (each within the scatter of the next).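

Within the data shown here, at the carbonyl carbon, cyclopentyloxy brings a five-membered ring of carbon only to a place that had so far held only open groups, yet in this assay the exchange for diethylamino gives no separable result (a number 10 percentage points lower from compound 2 to compound 4 (within the scatter)). The exchange for propyl reads the same way (no change at the digits printed from compound 1 to compound 4 (within the scatter)), so propyl, diethylamino and cyclopentyloxy cannot be told apart on this carbonyl carbon at the one concentration tested. No measurement is available that bears on this result.

As far as these compounds go, it remains open whether a longer chain, a benzylamine or a carboxylic acid on this carbonyl carbon would move the number beyond the scatter. Also open, from the compounds shown here alone, is whether cyclopentyloxy would read the same with thiophen-3-yl in place of furan-2-yl on the saturated ring carbon.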